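The compounds below may be only part of what the source reports. "The series", "measured", "known", "first", "only" and "open" are said of these compounds alone.

Measured compounds:
- compound 1 `Cc1ccc2nc(N3CCCc4ccc(F)cc4C3)cc(NC(=O)CN)c2c1`: > 100000 nM in an ADME assay on HEp-2 cells (Homo sapiens) for cytotoxicity, read by CCK-8 assay, with a stated time of 5 days; on this read-out higher numbers stand for lower toxicity in this test and lower numbers for higher toxicity in this test; this value is a limit of the assay, not a number the limit of > 100000 nM in this assay, at which 1 of the 3 values shown sits.
- compound 2 `Cc1ccc2nc(N3CCCc4ccc(F)cc4C3)cc(NCC(N)=O)c2c1`: 22000 nM
- compound 3 `CC(=O)NCCNc1cc(N2CCCc3ccc(F)cc3C2)nc2ccc(C)cc12`: 66000 nM

Among the two numbers, compound 3 stands highest; the step of a 3.0-fold higher number from compound 2 to compound 3 (0.48 log units; beyond the scatter) separates it from compound 2. The step of an at least 1.5-fold lower number from compound 1 to compound 3 (0.18 log units; that floor lies within the scatter) is bounded only by a limit.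

Compound 4 `Cc1ccc2nc(N3CCCc4ccc(F)cc4C3)cc(NCCNC3COC3)c2c1` differs from compound 3 by oxetan-3-yl in place of acetyl on an amine nitrogen. Going by the values given here, both measured steps alter the same side chain, but neither swaps an acyl group for a saturated ring on the amine nitrogen; the one step beyond the scatter, from compound 2 to compound 3, kept the chain length while changing the terminal group, and the other is within the scatter. Among the compounds with values here, no step therefore argues for a large move in this assay, and the expected step of a 1.3-fold lower number from compound 3 to compound 4 (0.12 log units; within the scatter) is small in either direction. For compound 4 the estimate is 50000 nM (range 20000 nM to 120000 nM), with a fair chance that only a limit is reported.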

Compound 4, half-maximal cytotoxic concentration: > 100000 nM
Compound 4 ended at the assay's limit (the forecaster's own chance of this, stated with the estimate: 25%); middle value at least 2.0-fold (0.30 log units) away from the limit.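

Oxetan-3-yl in place of acetyl on an amine nitrogen gives an at least 1.5-fold higher number from compound 3 to compound 4 (0.18 log units; that floor lies within the scatter) in this assay, so a saturated ring is tolerated here without any sign of higher toxicity in this test, though that floor alone does not separate the two compounds. Measured against the carbamoyl side chain, the 2-((oxetan-3-yl)amino)ethyl side chain gives an at least 4.5-fold higher number from compound 2 to compound 4 (0.65 log units; beyond the scatter). The result for compound 4 is a limit of the assay, and its step to compound 1 cannot be read: the limit of > 100000 nM in this assay, at which 2 of the 4 values shown sit.

Open, from the compounds shown here alone, is how far compound 4 really lies from compound 3. Also open, going by these compounds, is whether a carboxylic acid or a longer chain on this amine nitrogen would read the same way.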